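Adding a fluoro group to compound 2

This account rests on a few compounds, and the source may have more. Where it says the series, first, only, none or still open, it means among the compounds named here.

Compound 1 `Fc1ccc2[nH]c(-c3cn(-c4ccccc4)nc3-c3ccccc3)nc2c1`: > 50000 nM
Compound 2 `Clc1ccc(-c2nn(-c3ccccc3)cc2-c2nc3ccccc3[nH]2)cc1`: > 50000 nM

In an ADME assay on HaCaT cells (Homo sapiens) for cytotoxicity, read by MTT assay, with a stated time of 48 h (a lower number here means a stronger inhibitor, a higher number a weaker inhibitor), compound 2 gives > 50000 nM, which is a limit of the assay and not a number. Compound 1 gives > 50000 nM, which is also a limit. Neither measured compound therefore gives a number, and no measured step can be read between them.

Compound 3 `Fc1ccc2[nH]c(-c3cn(-c4ccccc4)nc3-c3ccc(Cl)cc3)nc2c1` departs from compound 2 by a single change: fluoro in place of hydrogen on an aromatic carbon. The expectation rests on compound 1, which also carries a fluoro group and gives > 50000 nM in this assay. No step beyond the scatter is expected, in either direction, and the estimated change is a number no higher from compound 2 to compound 3 (the limit leaves the size open). Compound 3 will most likely be reported as a limit again. For compound 3 the estimated value is 50000 nM, with an expected range from 20000 nM to 100000 nM.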

Compound 3, half-maximal inhibitory concentration: > 50000 nM
Compound 3 ended at the assay's limit; the forecaster's own chance of this, stated with the estimate: 85%; the middle value lies on the limit itself.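

In this assay compound 3 gives > 50000 nM as a limit and not a number. No step can be read from compound 2 or compound 1 to compound 3, because all three values end at one limit: the limit of > 50000 nM in this assay, at which 3 of the 3 values shown sit.

The compounds shown leave open where their true values lie, and so whether fluoro or chloro in place of hydrogen changes anything in this assay.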